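Dimethylamino substitution on the methyl of compound 1

The source may report more compounds than this note shows. Statements on the series, on what has been measured and on what is new or still open speak of the compounds shown alone.

Among the compounds with values here, compound 1 `Cc1csc(NC(=O)c2cc(C(C)(C)C)nn2Cc2ccccc2)n1` is one of two compounds measured in a physicochemical assay for solubility, read by nephelometry, measured as kinetic solubility, at pH 6.5; on this read-out lower numbers stand for lower solubility and higher numbers for higher solubility. In this assay compound 1 gives only a limit, < 1.6 ug/mL, which is the limit of < 1.6 ug/mL in this assay, at which 1 of the 2 values shown sits. Compound 2 `NCc1csc(NC(=O)c2cccnn2)n1` gives 50 ug/mL in this assay. Within the data shown here, no step between these two measured compounds is given, so their values show only that compound 1 returns a limit and compound 2 a number. Compound 3 `CN(C)Cc1csc(NC(=O)c2cc(C(C)(C)C)nn2Cc2ccccc2)n1` differs from compound 1 by dimethylamino in place of hydrogen on a saturated chain carbon bound to an aromatic carbon. The change is expected to raise solubility beyond the usual scatter, by an at least 7.5-fold higher number from compound 1 to compound 3 (0.87 log units; beyond the scatter). Compound 3 is estimated at 12 ug/mL, between 2 ug/mL and 60 ug/mL.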

Compound 3, solubility: 25 ug/mL
For compound 3 the middle estimate is 2.1-fold (0.32 log units) below the measured one; low and high end bracket the measured number.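

In this assay, within the data shown here, dimethylamino in place of hydrogen on a saturated chain carbon bound to an aromatic carbon gives an at least 15-fold higher number from compound 1 to compound 3 (1.19 log units; beyond the scatter), the first step read at a single place. On the core of compound 1, this change gives compound 3 a number, 25 ug/mL. The value of compound 1 is a limit and not a number: the limit of < 1.6 ug/mL in this assay, at which 1 of the 3 values shown sits.

On these data alone, the full size of the step stays open. Also open, as far as these compounds go, is whether morpholine or a carboxylic acid at this place would give a step of similar size.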